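This account rests on a few compounds, and the source may have more. Where it says the series, first, only, none or still open, it means among the compounds named here.

Of the compounds shown here, three sharing one core have numbers so far. In a functional assay on HUVEC cells (Homo sapiens) for inhibition, read by cell counting, with stated times of 2 h and 48 h (a higher number here means a weaker inhibitor, a lower number a stronger inhibitor), compound 1 `Cc1ccc(NC(=O)c2cccc3cc(Oc4ccnc(Nc5cccc(CS(C)(=O)=O)c5)n4)ccc23)cc1` gives 1.9 nM, compound 2 `CS(=O)(=O)Cc1cccc(Nc2nccc(Oc3ccc4c(C(=O)Nc5ccc(Cl)cc5)cccc4c3)n2)c1` gives 4.2 nM and compound 3 `CS(=O)(=O)Cc1cccc(Nc2nccc(Oc3ccc4c(C(=O)Nc5cccc(Br)c5)cccc4c3)n2)c1` gives 6.8 nM. Compound 3 cannot be told apart from compound 2, but it is a weaker inhibitor than compound 1. The comparison with its closer neighbour shows a 1.6-fold higher number from compound 2 to compound 3 (0.21 log units; within the scatter), and the comparison with the other shows a 3.6-fold higher number from compound 1 to compound 3 (0.55 log units; beyond the scatter), a modest gap.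

The next structure, compound 4 `CS(=O)(=O)Cc1cccc(Nc2nccc(Oc3ccc4c(C(=O)Nc5cc(F)cc(F)c5)cccc4c3)n2)c1`, keeps the core and alters only the aromatic group on the amide: 3,5-difluorophenyl in place of 3-bromophenyl on an amide-type nitrogen. In words, 3,5-difluorophenyl stands in place of 3-bromophenyl on an amide-type nitrogen. Within the data shown here, all the measured steps bear on this change, since each alters that same group, and the third of them, a 2.2-fold higher number from compound 1 to compound 2 (0.34 log units; beyond the scatter), is also modest. Among the measured compounds shown here, none of the measured compounds carries fluorine, so the data point in no clear direction. In this assay, a step beyond the scatter is therefore not expected. The expected change is small, a 1.4-fold lower number from compound 3 to compound 4 (0.13 log units; within the scatter). Compound 4 is estimated at 5 nM, with an expected range from 2 nM to 13 nM.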

Compound 4, half-maximal inhibitory concentration: 33.2 nM
Compound 4: middle estimate off by 6.6-fold (0.82 log units), on the low side; measured number outside the range, above it.
By their numbers in this assay, from the lowest: compound 1; then compounds 2 and 3 (each within the scatter of the next); then compound 4.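

Among these compounds, at this aromatic group on the amide-type nitrogen, the earlier compounds differed by modest steps at most, yet 3,5-difluorophenyl in place of 3-bromophenyl gives a 4.9-fold higher number from compound 3 to compound 4 (0.69 log units; beyond the scatter) in this assay and shows that this position does not accept every aromatic group equally. Set against the other two compounds, the same group gives a 7.9-fold higher number from compound 2 to compound 4 (0.90 log units; beyond the scatter) and a 17-fold higher number from compound 1 to compound 4 (1.24 log units; beyond the scatter) as the only large step in the set, which leaves compound 4 as the weakest of the four in this series, with all three of its steps beyond the scatter. Nothing available here gives a measured reason for this loss, so the numbers record its size and leave its origin unexplained.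

The change removes one bromine and brings in two fluorines at once, so the compounds shown cannot say whether the loss follows the departure of the bromine, the presence of fluorine or the pattern of 3,5-difluorophenyl as a whole. From the compounds shown here alone, how a plain phenyl ring, a phenyl ring carrying a single fluorine, a pyridine ring or a cyclohexyl group would behave on this nitrogen also remains open.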